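Adding a Methoxy Group to a Weakly Tolerated Compound

The compounds below may be only part of what the source reports. "The series", "measured", "known", "first", "only" and "open" are said of these compounds alone.

Compound 1 `Cc1nc(SCC(=O)Nc2nc(-c3ccc(Cl)cc3)cs2)n(Nc2ccccc2)c1C` was tested in a functional assay on NCI/ADR-RES cells (Homo sapiens) for antiproliferative activity, read by sulforhodamine B assay, with a stated time of 48 h (a higher number here means that more compound is tolerated, a lower number that less compound is tolerated), where compound 1 gives 69900 nM. Going by the values given here, this is the only value shown as a number, so compound 1 stands alone among the measured compounds. The second measured compound, compound 2 `Cc1ccc(Nn2c(SCC(=O)Nc3nc(-c4ccccc4)cs3)nc(C)c2C)cc1`, returned no number: in this assay compound 2 gives > 100000 nM, which is a limit of the assay. The evidence at hand is thin, resting on (the limit of > 100000 nM in this assay, at which 1 of the 2 values shown sits).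

Compound 3 `COc1ccc(Nn2c(SCC(=O)Nc3nc(-c4ccc(Cl)cc4)cs3)nc(C)c2C)cc1` has not yet been measured. It differs from compound 1 by methoxy in place of hydrogen on an aromatic carbon, para to a large group. Among the compounds with values here, no measured pair shows this change, so the step from compound 1 to compound 3, a 1.1-fold higher number from compound 1 to compound 3 (0.06 log units; within the scatter), is expected to be none beyond the usual scatter. Compound 3 is therefore expected to give about 80000 nM, in a range from 35000 nM to 180000 nM.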

Compound 3, concentration lethal to 50% of the cells: > 100000 nM
Compound 3: a limit, no number (the forecaster's own chance of this, stated with the estimate: 40%); middle value at least 1.2-fold (0.09 log units) from the limit.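

Turning the phenyl of compound 1 into 4-methoxyphenyl gives an at least 1.4-fold higher number from compound 1 to compound 3 (0.15 log units; that floor lies within the scatter). Going by these compounds alone, this is the first direct reading of a change at this place, and it shows that methoxy here does not lower the number in this assay, so the added group brings no sign that less compound is tolerated. The true size of the step stays unknown, as compound 3 gives only a limit and the floor of the step does not clear the usual scatter: the limit of > 100000 nM in this assay, at which 2 of the 3 values shown sit.

The compounds shown leave open whether any other group at this place, such as an amine, a carboxylic acid or a longer chain, would give a measurable number. They also leave open whether a group placed elsewhere on this ring would behave as methoxy does here.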